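The compounds below may be only part of what the source reports. "The series", "measured", "known", "first", "only" and "open" are said of these compounds alone.

Compound 1 (`O=C(COC(=O)c1ccc(N2C(=O)C3CC=CCC3C2=O)cc1)c1ccccc1`) was tested in an assay on isolated protein for inhibition of metabotropic glutamate receptor 5 (Homo sapiens), tested at 10 uM (on this read-out lower numbers stand for less inhibition and higher numbers for more inhibition at the one concentration tested (going by the name of the read-out)), and gives 18%. Of the two numbers measured it is the lower one: compound 2 (`Cc1ccc(C(=O)COC(=O)c2ccc(N3C(=O)c4ccncc4C3=O)cc2)cc1C`) gives 33%, a value higher than that of compound 1 by more than the usual scatter. Compound 3 (`Cc1ccc(NC(=O)NCc2ccc(N3C(=O)C4CC=CCC4C3=O)cc2)cc1C`) is reported in this assay only as a limit, < 35%; (the limit of < 35% in this assay, at which 1 of the 3 values shown sits). Compound 4 (`COc1ccc(C(=O)COC(=O)c2ccc(N3C(=O)C4CC=CCC4C3=O)cc2)cc1`) is not yet measured and differs from compound 1 by methoxy in place of hydrogen on an aromatic carbon. No measured step of this kind exists among these compounds, so the expectation rests on compound 1 alone; a small rise in this assay, within or just beyond the scatter, is expected. The expected step is a number 7 percentage points higher from compound 1 to compound 4 (within the scatter). Compound 4 is thus estimated at 25%, with a likely range from 10% to 45%.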

Compound 4, a percentage reported as inhibition, at one concentration (the size of the read-out at that concentration, not a potency): 39%
The estimate for compound 4 lay 14 percentage points below the measured number; measured number inside the range.
By their numbers in this assay, from the lowest: compound 1; then compounds 2 and 4 (each within the scatter of the next).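

In this assay, methoxy in place of hydrogen on an aromatic carbon, para to a large group, gives a number 21 percentage points higher from compound 1 to compound 4 (beyond the scatter). This is the first step among these compounds that can be read at a single place, and it shows that the read-out responds to a change on this ring. The values shown offer no explanation for the step.

Going by these compounds, it remains open whether an amine or a longer chain such as butoxy at this position would give a similar step. On these data alone, whether methoxy would have the same effect on the core of compound 2 also remains open.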